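The source may report more compounds than this note shows. Statements on the series, on what has been measured and on what is new or still open speak of the compounds shown alone.

Working notes on a small set of thiocarbamate-linked chromanone ethers. Compound 1 `O=c1c(CSC(=S)N2CCN(c3ccccc3)CC2)coc2ccccc12` in a functional assay on LM7 cells (Homo sapiens) for antiproliferative activity, read by MTT assay, with a stated time of 72 h (on this read-out higher numbers stand for weaker inhibition and lower numbers for stronger inhibition), gives 2900 nM. Compound 2 `O=c1c(CSC(=S)N2CCCC2)coc2ccccc12` in this assay gives 6000 nM. Compound 3 `COc1ccc2oc(CSC(=S)N3CCCCC3)cc(=O)c2c1` in this assay gives 5000 nM. Compound 2 thus stands at the highest of the three numbers; compound 3 sits within the usual scatter of it, while compound 1 lies beyond the scatter on the lower side. No two of these three differ in only one place, so no single structural step can be read from the measured set.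

Compound 4 `CN1CCN(C(=S)SCc2coc3ccccc3c2=O)CC1` has not yet been measured. Relative to compound 2 the change is 4-methylpiperazin-1-yl in place of pyrrolidin-1-yl on a thiocarbonyl carbon. The nearest guide is that compound 1, which also carries a substituted piperazine on the thiocarbonyl carbon, shows a lower number than compound 2, but the two differ in more than one place. A small downward step is expected, close to the edge of the scatter. The expected step in this assay is a 1.3-fold lower number from compound 2 to compound 4 (0.12 log units; within the scatter). Compound 4 is estimated at 4500 nM, with a range from 2000 nM to 10000 nM.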

Compound 4, half-maximal inhibitory concentration: 17600 nM
Beside the measured number, compound 4's estimate is 3.9-fold (0.59 log units) below it; measured number above the stated range.
By their numbers in this assay, from the lowest: compounds 1, 3 and 2 (each within the scatter of the next, the first and the last beyond it); then compound 4.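

Within the data shown here, on a thiocarbonyl carbon, the ring is not interchangeable in this assay: 4-methylpiperazin-1-yl in place of pyrrolidin-1-yl gives a 2.9-fold higher number from compound 2 to compound 4 (0.47 log units; beyond the scatter), the first single-place reading at this position and a step toward weaker inhibition. On the amine nitrogen in a ring, methyl in place of phenyl gives a 6.1-fold higher number from compound 1 to compound 4 (0.78 log units; beyond the scatter), so the substituent on that nitrogen, and not the presence of the piperazine ring alone, separates these two compounds. No measurement at hand accounts for either step.

As far as these compounds go, it remains open where an unsubstituted piperazine, or a benzyl or acetyl group on that ring nitrogen, would fall relative to the phenyl and methyl compounds. Also open, from the compounds shown here alone, is whether either step carries over to the core of compound 3.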